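Anilinoquinone series: sulfamoyl in place of methoxycarbonyl

A few compounds are considered here, and "the series" means these few. Any claim that something is new, unique, unknown or untested is made for them only; others in the source may bear on it.

Measured so far:
compound 1 `COC(=O)c1ccc(NC2=CC(=O)c3ncncc3C2=O)cc1` — 2200 nM
compound 2 `O=C1C(Nc2ccc(CO)cc2)=CC(=O)c2ncncc21` — 3500 nM

In a functional assay on MIA PaCa-2 cells (Homo sapiens) for cytotoxicity, read by MTT assay, with a stated time of 72 h (on this read-out higher numbers stand for weaker inhibition and lower numbers for stronger inhibition), compound 1 gives 2200 nM, the lowest of the two numbers shown, yet the step of a 1.6-fold higher number from compound 1 to compound 2 (0.20 log units; within the scatter) lies within the scatter, so compound 1 and compound 2 cannot be told apart on this read-out. Compound 3 `NS(=O)(=O)c1ccc(NC2=CC(=O)c3ncncc3C2=O)cc1` differs from compound 1 by sulfamoyl in place of methoxycarbonyl on an aromatic carbon. Within the data shown here, no measured step involves a sulfamoyl group. Among the measured compounds shown here, the single step available, a 1.6-fold higher number from compound 1 to compound 2 (0.20 log units; within the scatter), replaced the same methoxycarbonyl with a hydroxymethyl and stayed within the scatter, so the one precedent for exchanging this group is a flat one. The step of a 1.1-fold higher number from compound 1 to compound 3 (0.06 log units; within the scatter) is therefore expected to stay within the scatter, with no direction favoured. The estimate for compound 3 in this assay is 2500 nM, with a range from 900 nM to 7000 nM.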

Compound 3, half-maximal inhibitory concentration: > 10000 nM
Compound 3 was reported as a limit; the forecaster's own chance of this, stated with the estimate: 5%; middle value at least 4.0-fold (0.60 log units) from the limit.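

Compound 3 stands in this assay only as a limit: the limit of > 10000 nM in this assay, at which 1 of the 3 values shown sits. At this position, on an aromatic carbon para to a large group, the exchange is not neutral: sulfamoyl in place of methoxycarbonyl gives an at least 4.5-fold higher number from compound 1 to compound 3 (0.65 log units; beyond the scatter), and sulfamoyl in place of hydroxymethyl gives an at least 2.8-fold higher number from compound 2 to compound 3 (0.45 log units; beyond the scatter). Among these compounds, compound 1 and compound 2 alone showed only a step within the scatter at this place, and sulfamoyl is the first group here to separate compounds on this read-out.

On these data alone, whether the weaker result is specific to sulfamoyl remains open: a carboxylic acid, an amine or a methyl sulfone at the same place would help test that. As far as these compounds go, the full size of both steps also remains open, with only a limit available for compound 3.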